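Swapping a methyl for a fluorine on the benzyloxy arm

The source may hold more compounds than are shown below. What is called first, only, known or untested is meant among the compounds shown, and "the series" means these compounds.

Two compounds anchor this short series. Compound 1 `Cc1ccc(NC(=O)NC(=O)c2ccc(OCc3ccccc3)cc2)cc1-c1nc2ccccc2[nH]1` is measured in a functional assay on SW-620 cells (Homo sapiens) for inhibition, read by MTT assay, with a stated time of 48 h (a lower number here means a stronger inhibitor, a higher number a weaker inhibitor), and gives 30100 nM. Compound 2 `Cc1ccc(COc2ccc(C(=O)NC(=O)Nc3ccc(C)c(-c4nc5ccccc5[nH]4)c3)cc2)cc1` carries a methyl in place of a hydrogen on an aromatic carbon of the benzyloxy arm, and in this assay compound 2 gives 26000 nM. The step of a 1.2-fold lower number from compound 1 to compound 2 (0.06 log units; within the scatter) is within the scatter, so the two numbers cannot be told apart; compound 2 is simply one of two very similar, weak values.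

Compound 3 `Cc1ccc(NC(=O)NC(=O)c2ccc(OCc3cccc(F)c3)cc2)cc1-c1nc2ccccc2[nH]1` is not yet measured. It differs from compound 2 by 3-fluorophenyl in place of 4-methylphenyl on a saturated chain carbon bound to an oxygen on an aromatic ring. Within the data shown here, the only measured step, a 1.2-fold lower number from compound 1 to compound 2 (0.06 log units; within the scatter), shows that changing a substituent on this outer ring did nothing beyond the scatter, though that step did not involve a fluorine. With nothing else to go on, the expectation for compound 3 is a number close to that of compound 2, and the expected step of a 1.2-fold higher number from compound 2 to compound 3 (0.06 log units; within the scatter) is small in either direction. Compound 3 is therefore estimated at 30000 nM in this assay, with a range from 10000 nM to 90000 nM.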

Compound 3, half-maximal inhibitory concentration: 39600 nM
Compound 3: middle estimate off by 1.3-fold (0.12 log units), on the low side; the measured number falls inside the stated range.
By their numbers in this assay, from the lowest: compounds 2, 1 and 3 (each within the scatter of the next).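

In this assay, the outer ring now carries a fluorine as well as a methyl, and the direct exchange of 4-methylphenyl for 3-fluorophenyl gives a 1.5-fold higher number from compound 2 to compound 3 (0.18 log units; within the scatter). Adding a fluorine to the outer ring gives a 1.3-fold higher number from compound 1 to compound 3 (0.12 log units; within the scatter), so neither comparison with the new compound can be told apart from repeat-measurement noise. Together with the earlier methyl step, this shows that two different small substituents on this ring leave the read-out unresolved, although no data here offer an explanation for that flat result.

Going by these compounds, whether this tolerance extends to groups unlike methyl and fluoro on the same ring, such as an amine, a carboxylic acid or a nitrile, remains open. On these data alone, it is also open whether a longer chain in place of the benzyl link, or a change elsewhere on the shared core, would move the number beyond the scatter, since all three compounds differ only on this outer ring.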